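The compounds below may be only part of what the source reports. "The series", "measured", "known", "first", "only" and "open" are said of these compounds alone.

Compound 1 `COc1cc(-c2nc3cc([N+](=O)[O-])ccc3[nH]2)ccc1O`: 55.2%
Compound 2 `CCCOc1ccc(-c2nc3cc(C(F)(F)F)ccc3[nH]2)cc1`: 19%
Compound 3 `COc1cc(-c2nc3cc(C(F)(F)F)ccc3[nH]2)ccc1O`: 97.7%

Of the compounds shown here, three have been measured in a functional assay on aorta (Rattus norvegicus, strain Wistar) for inhibition, with a stated time of 60 min; a lower number here means a smaller maximal response, a higher number a larger maximal response. Compound 1 gives 55.2% and stands second highest of the three numbers: compound 2 lies beyond the scatter below it, and compound 3 lies beyond the scatter above it. Among the compounds with values here, the only step between compounds that differ in a single place runs a number 42.5 percentage points higher from compound 1 to compound 3 (beyond the scatter), so exchanging one group on the shared core can move the maximal response a long way.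

Compound 4 `COc1ccc(-c2nc3cc([N+](=O)[O-])ccc3[nH]2)cc1OC` has not yet been measured. It differs from compound 1 in one place: methyl in place of hydrogen on an oxygen on an aromatic ring. Cut one bond further out, the change reads hydroxy to methoxy. Within the data shown here, no measured step of this kind exists, so the step from compound 1 to compound 4 has no direct precedent. Compound 2, which carries no hydroxy, gives 19%, while compound 3, which keeps the hydroxy, gives 97.7%, but these two differ in more than one place, so their values only hint that losing the hydroxy may go with a smaller response. For compound 4 a moderate downward step is therefore expected, a number 15.2 percentage points lower from compound 1 to compound 4 (beyond the scatter), with wide uncertainty. Compound 4 is estimated at 40%, in a range from 15% to 70%.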

Compound 4, largest response reached (Emax), in percent of the reference or control that the assay uses: 36.3%
Estimate against measurement, compound 4: 3.7 percentage points above; measured number inside the range.
By their numbers in this assay, from the lowest: compound 2; then compound 4; then compound 1; then compound 3.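

In this assay, exchanging hydroxy for methoxy gives a number 18.9 percentage points lower from compound 1 to compound 4 (beyond the scatter) on the nitro-bearing core. Within the data shown here, the earlier single-place step concerned only the exchange of nitro for trifluoromethyl, so this is the first direct reading of a change at the oxygen on the aromatic ring, and it shows that adding one methyl there is enough to move the maximal response beyond the usual scatter. The response does not vanish with this change, so the hydrogen on that oxygen is not required for compound 4 to give a measurable maximal response, but nothing measured here bears on why the number falls.

The compounds shown leave open whether hydroxy to methoxy would move the response in the same direction and by a similar amount on the trifluoromethyl-bearing core of compound 3, because this change can be read only on the nitro-bearing core. They also do not tell how the response would change with a longer chain on that oxygen, or with an amine or a carboxylic acid in place of the hydroxy.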